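The source may report more compounds than this note shows. Statements on the series, on what has been measured and on what is new or still open speak of the compounds shown alone.

Among the measured compounds shown here, compound 3, the structure `Cc1c(OCCCCOc2ccc(F)c(C(=O)O)c2)ccc(C(=O)CC2CCCC2)c1C`, gives in an assay on HEK293 cells for positive allosteric modulation of metabotropic glutamate receptor 3 (Rattus norvegicus), read by thallium flux, with a stated time of 2.5 min (on this read-out lower numbers stand for smaller maximal responses and higher numbers for larger maximal responses), a value of 12.6%, the lowest of the three numbers measured so far. Compound 1, with the structure `COC(=O)c1ccc(OCCCCOc2ccc(C(=O)CC3CCCC3)c(C)c2C)cc1`, gives in this assay 24.2%, and compound 2, with the structure `Cc1c(OCCCCOc2ccc(C(=O)O)c(Cl)c2)ccc(C(=O)CC2CCCC2)c1C`, gives 35.5%. Both sit above compound 3: a number 11.6 percentage points lower from compound 1 to compound 3 (beyond the scatter) and a number 22.9 percentage points lower from compound 2 to compound 3 (beyond the scatter), while a number 11.3 percentage points higher from compound 1 to compound 2 (beyond the scatter).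

Compound 4, the structure `Cc1c(OCCCCOc2ccc(C(=O)O)cc2)ccc(C(=O)CC2CCCC2)c1C`, has not yet been measured in this assay. It differs from compound 3 in one place: 4-carboxyphenyl in place of 3-carboxy-4-fluorophenyl on an oxygen on a saturated carbon. For the measured compounds named here, the steps that bear on this change are those from compound 1 and compound 2 to compound 3, since compound 2 carries a 4-carboxy-3-chlorophenyl group, the closest relative of the 4-carboxyphenyl that enters, and compound 2 stands highest of the three. The step from compound 2 to compound 3 is modest yet beyond the scatter, and the step from compound 1 to compound 3 is of the same sign and also beyond the scatter. Compound 4 is therefore expected to recover part of that ground, with a step of a number 15.4 percentage points higher from compound 3 to compound 4 (beyond the scatter). The estimate for compound 4 in this assay is 28%, with a range from 15% to 42%.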

Compound 4, largest response reached (reported as percent of maximum), in percent of the reference or control that the assay uses: 12.2%
Beside the measured number, compound 4's estimate is 15.8 percentage points above it, and the stated range ends above it.
By their numbers in this assay, from the lowest: compounds 4 and 3 (each within the scatter of the next); then compound 1; then compound 2.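

In this assay, putting 4-carboxyphenyl in place of 3-carboxy-4-fluorophenyl on an oxygen on a saturated carbon gives a number 0.4 percentage points lower from compound 3 to compound 4 (within the scatter), so the maximal response does not separate these two groups. The higher value of compound 2 does not carry over to the closely related 4-carboxyphenyl: hydrogen in place of chloro on an aromatic carbon gives a number 23.3 percentage points lower from compound 2 to compound 4 (beyond the scatter), which ties that value to the chloro in this pair. Hydrogen in place of methyl on an oxygen next to a carbonyl group gives a number 12 percentage points lower from compound 1 to compound 4 (beyond the scatter), so in this pair the free carboxylic acid stands below its methyl ester, whereas compound 2, also a carboxylic acid, stands above that ester. No measurement shown here accounts for these differences.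

The compounds shown leave open whether the higher value is particular to chloro or would also appear with a bromo or a trifluoromethyl group in its place. They also leave open whether a tetrazole or a primary amide in place of the carboxylic acid would give a response closer to that of compound 2 or to that of compound 4.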